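From Isopropylamide to Cyclopentylamide in Paw Edema Inhibition

The source may report more compounds than this note shows. Statements on the series, on what has been measured and on what is new or still open speak of the compounds shown alone.

Two amides built on one shared core have been measured so far. Compound 1 `COc1cc2c(cc1OC)C(CC(=O)N(C)C)CC2` carries a dimethylamino group on its carbonyl carbon, and in a functional assay on the whole organism (strain Wistar) for inhibition, with Rattus norvegicus as the target, read by paw edema, with stated times of 60 min and 1 h, at a dose of 100 mg/kg by the oral route (a lower number here means less inhibition, a higher number more inhibition at the dose given (going by the name of the read-out)), compound 1 gives 25%. Compound 2 `COc1cc2c(cc1OC)C(CC(=O)NC(C)C)CC2` carries an isopropylamino group in the same place, and in this assay compound 2 gives 31.3%. On the numbers shown, compound 2 sits alongside compound 1: the step of a number 6.3 percentage points higher from compound 1 to compound 2 (within the scatter) is within the scatter, so the two readings cannot be told apart.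

Compound 3 `COc1cc2c(cc1OC)C(CC(=O)NC1CCCC1)CC2` has not yet been measured. It differs from compound 2 in one place: cyclopentyl in place of isopropyl on an amide-type nitrogen. Both the group that leaves and the group that enters are made of carbon only, and the amide nitrogen keeps its single hydrogen.

For the measured compounds named here, the only recorded step that bears on this change is a number 6.3 percentage points higher from compound 1 to compound 2 (within the scatter), a swap of the group on the amide-type nitrogen that stayed within the scatter. The step of a number 1.3 percentage points lower from compound 2 to compound 3 (within the scatter) is therefore expected to stay within the scatter too. For compound 3 in this assay the estimate is 30%, with a range from 15% to 45%.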

Compound 3, a percentage reported as inhibition, in the whole organism at one dose (the size of the read-out at that dose, not a potency): 40.6%
Compound 3: middle estimate off by 10.6 percentage points, on the low side; low and high end bracket the measured number.
By their numbers in this assay, from the lowest: compounds 1, 2 and 3 (each within the scatter of the next, the first and the last beyond it).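

The step of a number 9.3 percentage points higher from compound 2 to compound 3 (within the scatter) shows that, in this assay, cyclopentyl in place of isopropyl on an amide-type nitrogen cannot be told apart from no change at all, even though the entering group brings a five-membered non-aromatic ring of carbon only. The pair of compound 1 and compound 3 does give something new: the step of a number 15.6 percentage points higher from compound 1 to compound 3 (beyond the scatter) is the first shown here to pass beyond the scatter, so the group on the carbonyl carbon can change the reading in a modest way when cyclopentylamino takes the place of dimethylamino. Nothing measured here explains this difference.

From the compounds shown here alone, whether a larger ring such as cyclohexyl, or a cyclopentyl ring carrying a hydroxyl group or an amine, would raise the reading further on the amide-type nitrogen remains open. A straight pentyl chain in the same place would also be informative, as it would help to show whether the ring itself counts or only the larger carbon group.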